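Chloro to Fluoro on a Fused Ring: Expected Potency

A few compounds are considered here, and "the series" means these few. Any claim that something is new, unique, unknown or untested is made for them only; others in the source may bear on it.

Measured compounds:
Compound 1, `O=C(O)CN1C(=O)/C(=C/c2nc3ccccc3n2Cc2ccc(F)cc2)SC1=S`, gives 1770 nM in a functional assay on Raji cells (Homo sapiens) for cytotoxicity, read by MTT assay, with a stated time of 48 h; a higher number here means a weaker inhibitor, a lower number a stronger inhibitor.
Compound 2, `O=C(O)CN1C(=O)/C(=C/c2nc3ccccc3n2Cc2ccc(Cl)cc2)SC1=S`, gives 11400 nM.
Compound 3, `O=C(O)CN1C(=O)/C(=C/c2nc3cc(Cl)ccc3n2Cc2ccccc2F)SC1=S`, gives 2780 nM.

Compound 1 and compound 2 share a core and differ in one place: fluoro in place of chloro on an aromatic carbon. That change gave a 6.4-fold lower number from compound 2 to compound 1 (0.81 log units; beyond the scatter). Compound 3 has a different core; the difference between the cores of compound 3 and compound 2 is not broken down here. Compound 3 and compound 1 lie within the scatter of each other, so no order between them is claimed.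

Compound 4, `O=C(O)CN1C(=O)/C(=C/c2nc3cc(F)ccc3n2Cc2ccccc2F)SC1=S`, has not been measured. It differs from compound 3 as follows: fluoro in place of chloro on an aromatic carbon. The place is not the same as before: in compound 1 the fluoro sits para to a large group, whereas in compound 4 it sits on a ring that is part of a fused system of two rings, meta to a fused ring and para to a fused ring. This is the same kind of change, not the same change.

Compound 4 is expected to give 1500 nM in this assay, between 500 nM and 5000 nM. For compound 4 this means an expected step of a 1.9-fold lower number from compound 3 to compound 4 (0.27 log units; within the scatter). For the measured compounds named here, the expectation rests on the step of a 6.4-fold lower number from compound 2 to compound 1 (0.81 log units; beyond the scatter), which points toward a lower number, tempered by the place being different and by there being only one such step to draw on.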

Compound 4, half-maximal inhibitory concentration: 20400 nM
Compound 4: middle estimate off by 14-fold (1.13 log units), on the low side; measured number outside the range, above it.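

In this assay, putting fluoro in place of chloro on the fused ring system gave a 7.3-fold higher number from compound 3 to compound 4 (0.87 log units; beyond the scatter), which runs opposite to the earlier step, and the two steps clearly differ: the same change on two cores in this assay, a 6.4-fold lower number (0.81 log units; beyond the scatter) from compound 2 to compound 1 and a 7.3-fold higher number (0.87 log units; beyond the scatter) from compound 3 to compound 4, 47-fold (1.67 log units) apart, beyond the scatter of two such steps. This shows that, in this series, the direction of this change cannot simply be carried from one core to another, since the same swap of one atom for another lowered the number in one pair and raised it in the other. It does not show what lies behind the reversal, since the two pairs differ both in their cores and in where the change sits, and two steps cannot separate those factors.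

The compounds shown leave open how this change behaves when only the core differs and the place stays the same. They also leave open whether another group at the place held by chloro in compound 3 and fluoro in compound 4, such as a methyl, a methoxy or a nitrile, would give a number closer to that of compound 3 or compound 4.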